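Anilino substituent on a shared core: methyl to nitro

The source may report more compounds than this note shows. Statements on the series, on what has been measured and on what is new or still open speak of the compounds shown alone.

Series with a common core carrying a (4-(trifluoromethyl)benzyl)thio group and a varied amine. Compound 1 `CCCCCCCCCCCCNc1nc(SCc2ccc(C(F)(F)F)cc2)nc2ccccc12` bears a dodecylamino group; in a functional assay on MGC-803 cells (Homo sapiens) for cytotoxicity, read by MTT assay, with a stated time of 72 h (a higher number here means a weaker inhibitor, a lower number a stronger inhibitor), compound 1 gives only a limit, > 50000 nM, and no number. Compound 2 `Cc1ccccc1Nc1nc(SCc2ccc(C(F)(F)F)cc2)nc2ccccc12` carries a (2-methylphenyl)amino group and gives 24400 nM in this assay. Among the compounds with values here, compound 2 thus stands as the only compound of the pair with a measured number; the other entry is the assay limit (the limit of > 50000 nM in this assay, at which 1 of the 2 values shown sits), so no ordering beyond that can be read from the two.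

Compound 3 `O=[N+]([O-])c1ccc(Nc2nc(SCc3ccc(C(F)(F)F)cc3)nc3ccccc23)cc1` is the next case: 4-nitrophenyl in place of 2-methylphenyl on a nitrogen on an aromatic ring, i.e. (2-methylphenyl)amino to (4-nitrophenyl)amino. Within the data shown here, no measured step between two compounds that differ in a single place is available, so the expected size of the change in this assay rests on the change itself; a small shift toward stronger inhibition, close to the usual scatter, is the expectation, written as a 1.4-fold lower number from compound 2 to compound 3 (0.13 log units; within the scatter). On that basis compound 3 is estimated at 18000 nM in this assay, with a range from 6000 nM to 50000 nM.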

Compound 3, half-maximal inhibitory concentration: 8170 nM
The estimate for compound 3 lay 2.2-fold (0.34 log units) above the measured number, and the stated range covers the measured number.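

Within the data shown here, on the nitrogen on an aromatic ring, 4-nitrophenyl in place of 2-methylphenyl gives the only measured step in this assay, a 3.0-fold lower number from compound 2 to compound 3 (0.48 log units; beyond the scatter), so the aryl group at this place can move the read-out by more than the scatter. The change alters both the substituent on the ring and its place on that ring, so this single step cannot assign the shift to either one. No measurement shown accounts for the step, which therefore stands as an observation without a cause.

Open, going by these compounds, is whether the shift belongs to the nitro group or to its place on the ring: 4-methylphenyl, 2-nitrophenyl and plain phenyl on the same nitrogen would separate these readings, and a nitrile or a carboxylic acid in the place of the nitro group would show whether the trend extends beyond this one pair. Also open, on these data alone, is how the aryl amines relate to alkyl amines, since the dodecyl compound offers no number for comparison and a shorter chain such as hexyl would be needed to connect the two kinds of amine.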